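This account rests on a few compounds, and the source may have more. Where it says the series, first, only, none or still open, it means among the compounds named here.

Compound 1, `O=C(/C=C\Nc1ccc(F)cc1)c1cn(-c2ccccc2)nc1-c1ccccc1`, carries a plain phenyl ring on its core and, in a functional assay on HT-29 cells (Homo sapiens) for antiproliferative activity, read by MTT assay, with a stated time of 48 h (a lower number here means a stronger inhibitor, a higher number a weaker inhibitor), compound 1 gives 6870 nM. Compound 2, `O=C(/C=C\Nc1ccc(F)cc1)c1cn(-c2ccccc2)nc1-c1ccc(F)cc1`, differs from it only by a fluoro in place of hydrogen on an aromatic carbon, and in this assay compound 2 gives 6500 nM. The step of a 1.1-fold lower number from compound 1 to compound 2 (0.02 log units; within the scatter) is within the scatter, so these two numbers are to be read as the same. Compound 2 thus stands as one of two values that do not differ from each other beyond what repeated measurements would show.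

Compound 3, `O=C(/C=C\Nc1ccc(F)cc1)c1cn(-c2ccccc2)nc1-c1ccc(Cl)cc1`, is the next change at the same position: chloro in place of fluoro on an aromatic carbon. Among the compounds with values here, the only measured step that bears on this position is a 1.1-fold lower number from compound 1 to compound 2 (0.02 log units; within the scatter), and it was within the scatter. Within the data shown here, no measured step involves a chloro group, so nothing here shows how chloro behaves on this ring. The expectation is therefore a step of about a 1.1-fold lower number from compound 2 to compound 3 (0.03 log units; within the scatter), that is none beyond the scatter. Compound 3 is estimated at 6000 nM, with a range from 2500 nM to 14000 nM.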

Compound 3, half-maximal inhibitory concentration: > 50000 nM
Compound 3: a limit, no number; the forecaster's own chance of this, stated with the estimate: 5%; middle value at least 8.3-fold (0.92 log units) from the limit.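

In this assay, compound 3 gives a limit of the assay and not a number: the limit of > 50000 nM in this assay, at which 1 of the 3 values shown sits. Even so, the limit is enough to set a floor on the size of the change, with an at least 7.6-fold higher number from compound 2 to compound 3 (0.88 log units; beyond the scatter), and the comparison with the plain phenyl ring gives an at least 7.2-fold higher number from compound 1 to compound 3 (0.86 log units; beyond the scatter). The earlier pair made this position look indifferent, since hydrogen and fluoro gave numbers within the scatter of each other, whereas chloro on the same aromatic carbon moves the number beyond the scatter toward a weaker inhibitor, so a swap of one heavy atom here can matter a great deal.

The three compounds do not show how far compound 3 really lies past the limit, nor why going from 4-fluorophenyl to 4-chlorophenyl has so large an effect when going from phenyl to 4-fluorophenyl has none beyond the scatter. On these data alone, it also stays open whether chloro is a lone case or whether other groups at this place, such as bromo, methyl, methoxy or an amine, would likewise push the number up.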